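A few compounds are considered here, and "the series" means these few. Any claim that something is new, unique, unknown or untested is made for them only; others in the source may bear on it.

Of the compounds shown here, three with a shared core have been measured in a physicochemical assay for lipophilicity, at pH 7.4; a lower number here means a more polar compound, a higher number a more lipophilic compound. Compound 1, `CC(C)CN(c1ccc(F)cc1)S(=O)(=O)c1ccc2c(c1)C(O)CC(C1CCOCC1)O2`, gives 3.39. Compound 2, `CCc1ccc(N(CC2CCC2)S(=O)(=O)c2ccc3c(c2)C(O)CC(C2CCOCC2)O3)cc1`, gives 4.01. Compound 3, `CCc1ccc(N(CC(C)C)S(=O)(=O)c2ccc3c(c2)C(O)CC(C2CCN(C(=O)C4CCCC4)CC2)O3)cc1`, gives 5.04. Compound 2 thus stands between the other two: its number lies above that of compound 1 and below that of compound 3, and both gaps fall beyond the usual scatter of this assay.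

Compound 4, `CCc1ccc(N(C2CCC2)S(=O)(=O)c2ccc3c(c2)C(O)CC(C2CCOCC2)O3)cc1`, is not yet measured. It differs from compound 2 in one place: cyclobutyl in place of cyclobutylmethyl on a sulfonamide nitrogen. Going by the values given here, no measured pair shows the effect of this change, so the expectation rests on the change alone, which removes one carbon. A small step downward in this assay is expected from compound 2 to compound 4, a number 0.36 log units lower from compound 2 to compound 4 (beyond the scatter), roughly at the edge of the scatter. Compound 4 is therefore estimated at 3.65, within the range 3.3 to 4.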

Compound 4, distribution coefficient: 3.69
Compound 4: middle estimate off by 0.04 log units, on the low side, within the range that was stated.
By their numbers in this assay, from the lowest: compounds 1 and 4 (each within the scatter of the next); then compound 2; then compound 3.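

Going by these compounds alone, this is the first one-place change measured at this position. On the sulfonamide nitrogen, cyclobutyl in place of cyclobutylmethyl gives, in this assay, a number 0.32 log units lower from compound 2 to compound 4 (beyond the scatter), a modest step. The number at this position therefore moves when the group goes from 5 heavy atoms to 4 while the four-membered ring stays. Nothing available here accounts for the size of this step.

A single pair cannot show how the number responds to other groups on this nitrogen, such as a longer carbon chain or a chain ending in an amine. As far as these compounds go, whether the same change gives a similar step elsewhere on the shared core also stays open.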